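This account rests on a few compounds, and the source may have more. Where it says the series, first, only, none or still open, it means among the compounds named here.

Measured so far:
compound 1 `COc1ccc2c(c1)C(=O)C(=O)N2CCCn1cc(COc2cc(=O)oc3ccccc23)nn1` — 56%
compound 2 `O=C1C(=O)N(CCCCn2cc(COc3cc(=O)oc4ccccc34)nn2)c2ccc([N+](=O)[O-])cc21` — 55%
compound 3 `O=C1C(=O)N(CCCCn2cc(COc3cc(=O)oc4ccccc34)nn2)c2ccc(Br)cc21` — 63%

In a functional assay on THP-1 cells (Homo sapiens) for inhibition, read by sulforhodamine B assay, with a stated time of 48 h, tested at 50 uM (a higher number here means more inhibition of growth at the concentration tested, a lower number less inhibition of growth), compound 1 gives 56%, the second highest of the three numbers, with compound 2 at 55% and compound 3 at 63%; both gaps to compound 1 lie within the scatter. Going by the values given here, the single measured step, a number 8 percentage points higher from compound 2 to compound 3 (within the scatter), exchanges one ring substituent and also stays within the scatter. Compound 4 `O=C1C(=O)N(CCCn2cc(COc3cc(=O)oc4ccccc34)nn2)c2ccc(Cl)cc21` differs from compound 1 by chloro in place of methoxy on an aromatic carbon. Among the compounds with values here, no measured step removes a methoxy or introduces a chloro, so the only guide is that one substituent exchange on the shared core left the readout essentially unchanged. A step of no more than the scatter is therefore expected, with a number 1 percentage points higher from compound 1 to compound 4 (within the scatter) as the estimated step. Compound 4 is expected at 57%, between 44% and 70%.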

Compound 4, percent growth inhibition at one concentration: 78%
Beside the measured number, compound 4's estimate is 21 percentage points below it; measured number above the stated range.
By their numbers in this assay, from the lowest: compounds 2, 1 and 3 (each within the scatter of the next); then compound 4.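

In this assay chloro in place of methoxy on an aromatic carbon gives a number 22 percentage points higher from compound 1 to compound 4 (beyond the scatter) and so shows that this position of the shared core can move the read-out past the scatter. The earlier substituent exchange, a number 8 percentage points higher from compound 2 to compound 3 (within the scatter), did not show this. Nothing at hand accounts for the step.

Still open, on these data alone, is whether a fluoro group or an amine at this position would give a number nearer that of compound 4 or that of compound 1. A single pair also cannot show whether the step holds on other chains.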